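The source may report more compounds than this note shows. Statements on the series, on what has been measured and on what is new or still open speak of the compounds shown alone.

Measured compounds:
Compound 1 `COc1cc(-c2cc(/C=C/C(=O)c3ccc(N)cc3)[nH]n2)cc(OC)c1OC`: > 100000 nM
Compound 2 `COc1cc(-c2cc(/C=C/C(=O)c3ccc(Cl)c(Cl)c3)[nH]n2)cc(OC)c1OC`: 96000 nM

In a functional assay on SR cells (Homo sapiens) for inhibition, read by sulforhodamine B assay, with a stated time of 48 h (a higher number here means that more compound is tolerated, a lower number that less compound is tolerated), compound 2 gives 96000 nM. Within the data shown here, this is the only true number in the set. Compound 1, which shares the core, reaches only (the limit of > 100000 nM in this assay, at which 1 of the 2 values shown sits), so its result is a limit of the assay rather than a number. Between these two compounds the change was 3,4-dichlorophenyl in place of 4-aminophenyl on the carbonyl carbon, and the step of an at least 1.0-fold lower number from compound 1 to compound 2 (0.01 log units; that floor lies within the scatter) is the sole measured step available.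

Compound 3 `COc1ccc(C(=O)/C=C/c2cc(-c3cc(OC)c(OC)c(OC)c3)n[nH]2)cc1OC` differs from compound 2 by 3,4-dimethoxyphenyl in place of 3,4-dichlorophenyl on a carbonyl carbon. Among the measured compounds shown here, the one measured step that touches the same carbonyl-bound phenyl ring sat at its floor and within the scatter, so it gives no reason to expect a shift beyond the scatter in this assay for this further change of the same ring. Compound 3 is therefore expected to land near compound 2, at an estimated 100000 nM, within 40000 nM to 250000 nM. The expected step of a 1.0-fold higher number from compound 2 to compound 3 (0.02 log units; within the scatter) is accordingly small, with a real chance that only a limit is reported.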

Compound 3, concentration lethal to 50% of the cells: > 100000 nM
Compound 3 ended at the assay's limit (the forecaster's own chance of this, stated with the estimate: 40%); the middle value sits exactly at the limit.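

In this assay, replacing 3,4-dichlorophenyl with 3,4-dimethoxyphenyl on the carbonyl carbon gives an at least 1.0-fold higher number from compound 2 to compound 3 (0.01 log units; that floor lies within the scatter), so this second readable change to the ring shows no difference beyond the scatter, even though the entering group carries hydrogen-bond acceptors and the leaving group has none. Compound 3 gives > 100000 nM, which is a limit of the assay and not a number. The step from compound 1 to compound 3 cannot be read, as both results are limits, and the set now sits mostly at the top of what the assay can report: the limit of > 100000 nM in this assay, at which 2 of the 3 values shown sit.

Still open, going by these compounds, is whether any group on this ring can bring the number clearly down in this assay, for example a trifluoromethyl group or a carboxylic acid in place of the chlorine atoms or methoxy groups. Also open, on these data alone, is whether a change elsewhere in the shared core, such as a longer chain between the carbonyl and the rest of the molecule, would give a true number well inside the range of the assay.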